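Tail flick series: nitrophenyl in place of fluorophenyl

The source may report more compounds than this note shows. Statements on the series, on what has been measured and on what is new or still open speak of the compounds shown alone.

Compound 1 `CC(=O)N1N=C(c2ccc(F)cc2)CC1c1cn(-c2ccccc2)nc1-c1ccc(F)cc1` and compound 2 `Fc1ccc(C2=NN(c3ccccc3)C(c3cn(-c4ccccc4)nc3-c3ccc(F)cc3)C2)cc1` share one core and differ only at a ring nitrogen. In a functional assay on the whole organism (Tail) with Rattus norvegicus as the target, in the tail flick test, with a stated time of 60 min, at a dose of 25 mg/kg by the oral route (on this read-out higher numbers stand for more inhibition at the one dose given (going by the name of the read-out) and lower numbers for less inhibition), compound 1 gives 43%, and in the same test compound 2 gives 41%. Among the compounds with values here, the only measured step in the set is a number 2 percentage points lower from compound 1 to compound 2 (within the scatter). Compound 2 thus stands level with compound 1 within the scatter, with no ranking between the pair on the numbers shown.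

Compound 3 `O=[N+]([O-])c1cccc(-c2nn(-c3ccccc3)cc2C2CC(c3ccc(F)cc3)=NN2c2ccccc2)c1` changes compound 2 elsewhere on the core: 3-nitrophenyl in place of 4-fluorophenyl on an aromatic carbon. Within the data shown here, no measured step touches this carbon or this kind of aryl exchange, and the one known step, a number 2 percentage points lower from compound 1 to compound 2 (within the scatter), concerns a ring nitrogen. Without any guide to direction, no step beyond the scatter is assumed, and the expected step is a number 1 percentage points lower from compound 2 to compound 3 (within the scatter), carried with a wide range. Compound 3 is therefore expected to give about 40% in this assay, with a range from 20% to 60%.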

Compound 3, a percentage reported as inhibition, in the whole organism at one dose (the size of the read-out at that dose, not a potency): 108%
Compound 3: middle estimate off by 68 percentage points, on the low side; measured number outside the range, above it.
By their numbers in this assay, from the lowest: compounds 2 and 1 (each within the scatter of the next); then compound 3.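

In this assay the exchange of 4-fluorophenyl for 3-nitrophenyl on an aromatic carbon gives a number 67 percentage points higher from compound 2 to compound 3 (beyond the scatter) and so stands apart from the exchange at the ring nitrogen, which gave a number 2 percentage points lower from compound 1 to compound 2 (within the scatter) on the shared core. This aromatic carbon is thus the first place in the series where a change moves the read-out beyond the scatter. Nothing available on these compounds accounts for the size of this step.

The exchange changes both the substituent and where it stands on the phenyl ring, and the compounds shown do not separate the two; 4-nitrophenyl or 3-fluorophenyl at this carbon would do so. Also open, as far as these compounds go, is whether an amine or a carboxylic acid on this phenyl ring would keep the gain, and whether it holds with acetyl on the ring nitrogen.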